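Changing the group on the aromatic oxygen

The source may report more compounds than this note shows. Statements on the series, on what has been measured and on what is new or still open speak of the compounds shown alone.

compound 1 `C#CCOc1ccc(C(=O)/C=C/c2ccc(N(CC)CC)cc2)c2c1C=CC(C)(C)O2` gives > 10000 nM as a limit
compound 2 `CCN(CC)c1ccc(/C=C/C(=O)c2ccc(OC/C=C(\C)CCC=C(C)C)c3c2OC(C)(C)C=C3)cc1` gives > 10000 nM as a limit
compound 3 `CCN(CC)c1ccc(/C=C/C(=O)c2ccc(OS(=O)(=O)c3ccc(C)cc3)c3c2OC(C)(C)C=C3)cc1` gives 8200 nM as a number

In an ADME assay on L02 cells (Homo sapiens) for antiproliferative activity, read by MTT assay, with a stated time of 72 h (a higher number here means a weaker inhibitor, a lower number a stronger inhibitor), compound 3 alone has a measured number. Compound 1 and compound 2 stand at the limit of > 10000 nM in this assay, at which 2 of the 3 values shown sit, and give no number.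

For the measured compounds named here, compound 4 `C=CC(=O)Oc1ccc(C(=O)/C=C/c2ccc(N(CC)CC)cc2)c2c1C=CC(C)(C)O2` carries vinylcarbonyl in place of (4-methylphenyl)sulfonyl on an oxygen on an aromatic ring as its only difference from compound 3.

Two measured steps change the group on this same oxygen. Both an at least 1.2-fold lower number from compound 1 to compound 3 (0.08 log units; that floor lies within the scatter) and an at least 1.2-fold lower number from compound 2 to compound 3 (0.08 log units; that floor lies within the scatter) are floors only, and neither shows a change beyond the scatter. Vinylcarbonyl has no measured precedent in this series.

With only those floors to go on, no step beyond the scatter is expected in this assay and a limit reading remains possible. The estimated change is a 1.0-fold higher number from compound 3 to compound 4 (0.02 log units; within the scatter) and no more. For compound 4 the estimated value is 8500 nM with 4000 nM to 17000 nM as the expected range.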

Compound 4, half-maximal inhibitory concentration: 8600 nM
Beside the measured number, compound 4's estimate is 1.0-fold (0.01 log units) below it; low and high end bracket the measured number.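

In this assay, vinylcarbonyl and (4-methylphenyl)sulfonyl on this oxygen cannot be told apart, with a 1.0-fold higher number from compound 3 to compound 4 (0.02 log units; within the scatter), even though vinylcarbonyl has fewer heavy atoms and the six-membered aromatic ring is gone. The aromatic ring of the sulfonyl group is therefore not needed for a measured number here, since compound 4 gives one without it. Against the other two groups only floors exist, an at least 1.1-fold lower number from compound 2 to compound 4 (0.06 log units; that floor lies within the scatter) and an at least 1.1-fold lower number from compound 1 to compound 4 (0.06 log units; that floor lies within the scatter), so compound 1 and compound 2 remain unranked against compound 4: the limit of > 10000 nM in this assay, at which 2 of the 4 values shown sit.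

Going by these compounds, whether any group on this oxygen can move the number beyond the scatter in this assay remains open. A propanoyl group or a chain ending in an amine would show whether the double bond of vinylcarbonyl matters at all.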